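This account rests on a few compounds, and the source may have more. Where it says the series, first, only, none or still open, it means among the compounds named here.

Measured in a functional assay on P388 cells (Mus musculus) for inhibition, read by MTT assay; on this read-out lower numbers stand for stronger inhibition and higher numbers for weaker inhibition:
- compound 1 `OC1C#CCCCCC#C/C1=C\c1ccc2ccccc2c1`: 3600 nM
- compound 2 `CC(=O)OC1C#CCCCCC#C/C1=C\c1cccc2ccccc12`: 2400 nM
- compound 3 `CC(=O)OC1C#CCCCCC#C/C1=C\c1ccc2ccccc2c1`: 2800 nM

Compound 3 holds the second highest of the three numbers in this assay; compound 2 lies nearest and compound 1 furthest, and both gaps are within the scatter. For the measured compounds named here, the one single-point step measured so far, a 1.3-fold lower number from compound 1 to compound 3 (0.11 log units; within the scatter), stayed within the scatter as well.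

Compound 4 `COCC(=O)OC1C#CCCCCC#C/C1=C\c1ccc2ccccc2c1` differs from compound 3 by methoxy in place of hydrogen on a saturated chain carbon bound to a carbonyl carbon. Going by the values given here, no measured pair probes a change on the acyl chain of the ester; the only step that touches that part of the molecule, a 1.3-fold lower number from compound 1 to compound 3 (0.11 log units; within the scatter), was flat. On that basis the step of no change at the digits printed from compound 3 to compound 4 (within the scatter) is expected to be none beyond the scatter. Compound 4 is therefore estimated at 2800 nM, with a range of 1400 nM to 5600 nM.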

Compound 4, half-maximal inhibitory concentration: 28000 nM
Estimate against measurement, compound 4: 10-fold (1.00 log units) below; the measured number lies above the stated range.
By their numbers in this assay, from the lowest: compounds 2, 3 and 1 (each within the scatter of the next); then compound 4.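

The acyl chain of the ester is not a silent position: in this assay, methoxy in place of hydrogen on a saturated chain carbon bound to a carbonyl carbon gives a 10-fold higher number from compound 3 to compound 4 (1.00 log units; beyond the scatter) and so weakens inhibition. Read from the free hydrogen on the oxygen, (methoxymethyl)carbonyl gives a 7.8-fold higher number from compound 1 to compound 4 (0.89 log units; beyond the scatter), whereas acetyl gives a 1.3-fold lower number from compound 1 to compound 3 (0.11 log units; within the scatter), so acylation alone does not carry the loss. Nothing on hand gives a cause for this step.

Still open, on these data alone, is whether the loss follows the methoxy oxygen or the longer chain alone. A plain ethyl or an amine at the same carbon would separate the two.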